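The source may hold more compounds than are shown below. What is called first, only, known or untested is meant among the compounds shown, and "the series" means these compounds.

Measured so far in a physicochemical assay for lipophilicity, read by HPLC, at pH 3; on this read-out lower numbers stand for lower lipophilicity and higher numbers for higher lipophilicity:
compound 1 `COc1ccc(C(=O)/C=C/c2ccc(OCCNc3ccnc4cc(Cl)ccc34)c(OC)c2)c(OC)c1` gives 2.8
compound 2 `COc1cc(/C=C/C(C)=O)ccc1OCc1cn(-c2ccnc3cc(Cl)ccc23)nn1` gives 3.5
compound 3 `COc1ccc(C(=O)/C=C/c2cc(CN3CCN(c4ccnc5cc(Cl)ccc45)CC3)c(O)c(OC)c2)c(OC)c1` gives 2.1

Compound 1 stands second highest of the three numbers in this assay. Its nearest neighbour is compound 3, whose value is lower by a gap beyond the usual scatter; compound 2 sits higher by a gap of the same size, also beyond the scatter. No two of these compounds differ in one place only, so no single step between measured values is counted.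

The next compound, compound 4 `COc1cc(/C=C/C(C)=O)ccc1OCCNc1ccnc2cc(Cl)ccc12`, is compound 1 with one change: methyl in place of 2,4-dimethoxyphenyl on a carbonyl carbon. Read one bond further out, the (2,4-dimethoxyphenyl)carbonyl of compound 1 becomes an acetyl in compound 4. Among the measured compounds shown here, compound 2 also carries an acetyl, but it differs from compound 4 in the linker as well, so its value stands on its own and is no guide to this step.

Nothing measured shows this change directly. A step downward, beyond the scatter, is expected for compound 4, of the size a number 0.90 log units lower from compound 1 to compound 4 (beyond the scatter). Compound 4 is therefore estimated at 1.9 in this assay, within a range of 1.2 to 2.6.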

Compound 4, distribution coefficient: 1.8
The estimate for compound 4 lay 0.10 log units above the measured number; the range from low to high includes it.
By their numbers in this assay, from the lowest: compounds 4 and 3 (each within the scatter of the next); then compound 1; then compound 2.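

Working notes on the series: in this assay, the series now has its first single-place comparison, a number 1.00 log units lower from compound 1 to compound 4 (beyond the scatter), for methyl in place of 2,4-dimethoxyphenyl on a carbonyl carbon. This shows that the read-out at this position responds to the group on the carbonyl carbon, with the shared remainder of compound 1 and compound 4 held constant, and that the step from the larger group to the methyl lies beyond the usual scatter. No supporting measurement bears on the origin of this step, so the pair gives its direction and size but no explanation.

The pair changes the aromatic ring and both methoxy groups together, leaving open how much of the step would remain with an unsubstituted phenyl, an ethyl or a longer alkyl chain, or a dimethylamino group on the same carbonyl carbon. Also open is whether the same exchange would give a step of similar size on the linkers of compound 2 and compound 3, since neither compound has a single-place partner among those shown.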